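Removing a Ring Phenyl from a Weak Methylene Lactam

The source may hold more compounds than are shown below. What is called first, only, known or untested is meant among the compounds shown, and "the series" means these compounds.

Measured compounds:
Compound 1, `C=C1CN(C)N(c2ccc(Br)cc2)C1=O`: 51800 nM
Compound 2, `C=C1C(=O)N(c2ccccc2)N(C)C1c1ccccc1`: 40900 nM

The two compounds were tested in a functional assay on HL-60 cells (Homo sapiens) for inhibition, read by MTT assay, with a stated time of 48 h; a higher number here means a weaker inhibitor, a lower number a stronger inhibitor. There compound 1 gives 51800 nM, and compound 2 gives 40900 nM; the two numbers sit within the scatter of each other, so neither stands apart. Compound 3, `C=C1CN(C)N(c2ccccc2)C1=O`, has not been measured. It differs from compound 2 in one place: hydrogen in place of phenyl on a saturated ring carbon. Going by the values given here, no pair of measured compounds shows the effect of this change on its own, so the step can only be expected from the two weak numbers in hand. Both are far from potent, and the change removes a large group without adding one, so the step from compound 2 to compound 3 is expected to be small, probably toward a weaker value, and possibly within the scatter, a 1.5-fold higher number from compound 2 to compound 3 (0.17 log units; within the scatter). Compound 3 is therefore estimated at 60000 nM, with a range from 25000 nM to 150000 nM.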

Compound 3, half-maximal inhibitory concentration: 45700 nM
For compound 3 the middle estimate is 1.3-fold (0.12 log units) above the measured one; the measured number falls inside the stated range.
By their numbers in this assay, from the lowest: compounds 2, 3 and 1 (each within the scatter of the next).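

In this assay hydrogen in place of phenyl on a saturated ring carbon gives a 1.1-fold higher number from compound 2 to compound 3 (0.05 log units; within the scatter) and so shows directly, in a comparison of one place, that the phenyl group at this position can be lost without the number leaving the scatter. Compound 3 also gives a second one-place comparison: hydrogen in place of bromo on an aromatic carbon gives a 1.1-fold lower number from compound 1 to compound 3 (0.05 log units; within the scatter) and likewise stays within the scatter. Nothing measured here accounts for these small steps.

The compounds shown leave open whether an amine, a carboxylic acid or a longer chain on that saturated ring carbon would move the number beyond the scatter. The same question stands for a methoxy group or a nitrile on the aromatic carbon that carries bromo in compound 1.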